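A few compounds are considered here, and "the series" means these few. Any claim that something is new, unique, unknown or untested is made for them only; others in the source may bear on it.

Measured so far:
compound 1 `Brc1cccc(CSc2nnc(-c3ccncc3)n2-c2ccccc2)c1` — 10000 nM
compound 2 `O=C(CSc1nnc(-c2ccncc2)n1-c1ccccc1)N/N=C/c1ccc(Cl)cc1` — 9930 nM
compound 3 `O=C(CSc1nnc(-c2ccncc2)n1-c1ccccc1)N/N=C/c1ccc(F)cc1` — 12300 nM

In a functional assay on MCF7 cells (Homo sapiens) for inhibition, read by MTT assay, with a stated time of 48 h (on this read-out lower numbers stand for stronger inhibition and higher numbers for weaker inhibition), compound 3 gives 12300 nM, the highest of the three numbers shown, but its gaps to compound 1 and to compound 2 are both within the scatter, so the three compounds cannot be put in order. Compound 4 `O=C(CSc1nnc(-c2ccncc2)n1-c1ccccc1)N/N=C/C=C/c1ccccc1` differs from compound 3 by 2-phenylethenyl in place of 4-fluorophenyl on a carbon with a double bond to nitrogen. Among the compounds with values here, the one measured step that bears on this place in the molecule is a 1.2-fold higher number from compound 2 to compound 3 (0.09 log units; within the scatter), an exchange of one halogen for another on the same group that now gives way to 2-phenylethenyl; it was within the scatter. Within the data shown here, no measured pair shows the effect of replacing the whole aromatic group by a chain-bearing one, so the expectation rests on the flatness of the series so far. No step beyond the scatter is expected in this assay from the change in compound 4. The estimate for compound 4 is 10000 nM, with a range from 4000 nM to 25000 nM. That estimate means an expected step of a 1.2-fold lower number from compound 3 to compound 4 (0.09 log units; within the scatter), within the scatter.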

Compound 4, half-maximal inhibitory concentration: 11200 nM
The estimate for compound 4 lay 1.1-fold (0.05 log units) below the measured number, within the range that was stated.
By their numbers in this assay, from the lowest: compounds 2, 1, 4 and 3 (each within the scatter of the next).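

In this assay, 2-phenylethenyl in place of 4-fluorophenyl on the carbon with a double bond to nitrogen gives a 1.1-fold lower number from compound 3 to compound 4 (0.04 log units; within the scatter), and the same group in place of 4-chlorophenyl gives a 1.1-fold higher number from compound 2 to compound 4 (0.05 log units; within the scatter). Within the data shown here, until now only one halogen in exchange for another had been read at this place; the exchange of the whole group, which removes the halogen and adds 1 double bond outside aromatic rings, also stays within the scatter across compounds 2, 3 and 4. No supporting measurement bears on the reason for this flat result.

Compounds 2, 3 and 4 all keep a six-membered aromatic ring of carbon only in this group. As far as these compounds go, whether an amine, a carboxylic acid or a longer saturated chain at this place would give a step beyond the scatter stays open.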